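The source may hold more compounds than are shown below. What is called first, only, known or untested is meant among the compounds shown, and "the series" means these compounds.

Among the measured compounds shown here, in a functional assay on HCT-116 cells (Homo sapiens) for inhibition, read by colorimetric assay, with a stated time of 3 days (on this read-out lower numbers stand for stronger inhibition and higher numbers for weaker inhibition), compound 1 `COc1ccc(-c2cnc(NC(=O)CCCCCCNC(=O)C(O)(O)C(F)(F)F)s2)cc1` gives 930 nM, the only true number so far in this small set. Compound 2 `O=C(CCCCCCNC(=O)C(O)C(F)(F)F)Nc1nccs1` reads > 40000 nM, and this is a limit of the assay. The next compound to be read is compound 3 `CCOc1ccc(-c2cnc(NC(=O)CCCCCCNC(=O)C(O)(O)C(F)(F)F)s2)cc1`, which turns 4-methoxyphenyl to 4-ethoxyphenyl: methyl in place of hydrogen on a saturated chain carbon bound to an oxygen on an aromatic ring. This places methyl in place of hydrogen on a saturated chain carbon bound to an oxygen on an aromatic ring, with the rest of the structure unchanged. For the measured compounds named here, no measured pair shows a change of this kind, so the expectation is anchored on compound 1 at 930 nM alone. No shift beyond the scatter is expected in this assay, in either direction. The estimated 1.1-fold lower number from compound 1 to compound 3 (0.04 log units; within the scatter) is therefore small. For compound 3 the expected value is 850 nM, within an estimated range of 350 nM to 2000 nM.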

Compound 3, half-maximal inhibitory concentration: 4050 nM
For compound 3 the middle estimate is 4.8-fold (0.68 log units) below the measured one, and the stated range ends below it.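

In this assay, among the compounds shown here, the change from 4-methoxyphenyl to 4-ethoxyphenyl gives the first single-place comparison, and it registers: a 4.4-fold higher number from compound 1 to compound 3 (0.64 log units; beyond the scatter). One added methyl on the saturated chain carbon bound to an oxygen on an aromatic ring is therefore enough to move the read-out beyond the scatter, so this position is not indifferent to change in this assay. Compound 2 stands as a limit, not a number, and adds nothing to this step: the limit of > 40000 nM in this assay, at which 1 of the 3 values shown sits.

As far as these compounds go, whether the direction of this step holds for a longer chain such as propoxy, or for a hydroxy group or an amine at the same place, remains open. A single pair sets no pattern and gives no reason for the shift.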